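Boronic acid chalcones: chloro to ethyl on the aryl ring

The source may report more compounds than this note shows. Statements on the series, on what has been measured and on what is new or still open speak of the compounds shown alone.

Compound 1 `O=C(/C=C/c1ccc2c(c1)B(O)OC2)c1cccs1` gives 13800 nM in a toxicity assay on MCF-10A cells (Homo sapiens) for cytotoxicity, read by MTT assay, with a stated time of 48 h; on this read-out lower numbers stand for stronger inhibition and higher numbers for weaker inhibition.
Compound 2 `Cn1cccc1C(=O)/C=C/c1ccc2c(c1)B(O)OC2` reaches only the assay limit, > 100000 nM.
Compound 3 `O=C(/C=C/c1ccc2c(c1)B(O)OC2)c1ccc(Cl)cc1` gives 12100 nM.

Compound 3 and compound 1 lie within the scatter of each other, a 1.1-fold lower number from compound 1 to compound 3 (0.06 log units; within the scatter). Compound 2 is a limit, (the limit of > 100000 nM in this assay, at which 1 of the 3 values shown sits), and stands apart by an at least 8.2-fold lower number from compound 2 to compound 3 (0.91 log units; beyond the scatter). Compound 4 `CCc1ccc(C(=O)/C=C/c2ccc3c(c2)B(O)OC3)cc1` differs from compound 3 by ethyl in place of chloro on an aromatic carbon. Within the data shown here, every measured step exchanges the whole aryl group on the carbonyl carbon; no step alters a substituent on the 4-chlorophenyl ring, so none bears directly on this change. A step within the scatter is therefore the working assumption, with a 1.0-fold lower number from compound 3 to compound 4 (0.00 log units; within the scatter) expected. Compound 4 is estimated at 12000 nM, within 5000 nM to 30000 nM.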

Compound 4, half-maximal inhibitory concentration: 8800 nM
The estimate for compound 4 lay 1.4-fold (0.13 log units) above the measured number; the range from low to high includes it.
By their numbers in this assay, from the lowest: compounds 4, 3 and 1 (each within the scatter of the next). At a limit, above all of these: compound 2.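

With a 1.4-fold lower number from compound 3 to compound 4 (0.14 log units; within the scatter) in this assay, the series gains its first reading of a substituent exchange on the ring, rather than of the whole aryl group on the carbonyl carbon. Para to a large group, ethyl in place of chloro therefore leaves the number within the scatter. No measurement shown here bears on the reason for this step.

Going by these compounds, whether an amine, a carboxylic acid or a longer chain at this place would also stay within the scatter remains open. Also open, on these data alone, is whether ethyl would behave the same way on another position of this ring.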